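This account rests on a few compounds, and the source may have more. Where it says the series, first, only, none or still open, it means among the compounds named here.

Measured so far in an assay on thoracic aorta for binding affinity to Endothelin-1 receptor (Rattus norvegicus); a higher number here means a weaker inhibitor, a lower number a stronger inhibitor: compound 1 `Cc1onc(NS(=O)(=O)c2cccc3c(N(C)C)cccc23)c1C` gives 15 nM; compound 2 `Cc1noc(NS(=O)(=O)c2ccc3cccc(N)c3c2)c1C` gives 9800 nM; compound 3 `Cc1noc(NS(=O)(=O)c2ccc3cccc(N(C)C)c3c2)c1C` gives 31500 nM.

Compound 3 stands highest of the three numbers in this assay; its nearest neighbour is compound 2, and compound 1 lies far below both. Among the compounds with values here, the one step that touches the same position, a 3.2-fold higher number from compound 2 to compound 3 (0.51 log units; beyond the scatter), was modest and beyond the scatter.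

Compound 4 `CC(=O)Nc1cccc2ccc(S(=O)(=O)Nc3onc(C)c3C)cc12` is the next member: acetamido in place of dimethylamino on an aromatic carbon. Within the data shown here, no measured pair covers acetamido directly, so the step from compound 2 to compound 3 is the only guide, and it shows that substitution at this carbon moves the number only moderately. A step of similar size in the reverse direction is expected, giving a 2.6-fold lower number from compound 3 to compound 4 (0.42 log units; beyond the scatter). For compound 4 the estimate is 12000 nM, with a range from 3000 nM to 45000 nM.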

Compound 4, half-maximal inhibitory concentration: 27500 nM
Estimate against measurement, compound 4: 2.3-fold (0.36 log units) below, and the stated range covers the measured number.
By their numbers in this assay, from the lowest: compound 1; then compound 2; then compounds 4 and 3 (each within the scatter of the next).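

Acetamido and dimethylamino on this aromatic carbon read alike in this assay with a 1.1-fold lower number from compound 3 to compound 4 (0.06 log units; within the scatter) as the step, although acetamido carries a hydrogen-bond donor and dimethylamino none. Acetyl on the nitrogen gives a 2.8-fold higher number from compound 2 to compound 4 (0.45 log units; beyond the scatter) as its step, in the same direction as a 3.2-fold higher number from compound 2 to compound 3 (0.51 log units; beyond the scatter) as the earlier step, so both replacements of amino raise the number. No available data bear on the reason for this result.

As far as these compounds go, the effect of a carboxylic acid or a longer acyl chain on this carbon remains open. So does whether acetamido would give a similar number on the core of compound 1.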